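Dichloro purine to monochloro purine: cytotoxicity notes

The compounds below may be only part of what the source reports. "The series", "measured", "known", "first", "only" and "open" are said of these compounds alone.

Measured so far:
compound 1 `ClCc1cccc(Cn2cnc3nc(Cl)nc(Cl)c32)c1` — a functional assay on SK-OV-3 cells (Homo sapiens) for cytotoxicity, read by sulforhodamine B assay, with a stated time of 48 h; a lower number here means that less compound is tolerated, a higher number that more compound is tolerated: "not determined" (no result reported)
compound 2 `ClCc1ccccc1Cn1cnc2ncnc(Cl)c21` — this assay: 85100 nM

Compound 1 stands nowhere on the numbers: no result is reported for it in this assay, so its position cannot be given. Compound 3 `ClCc1cccc(Cn2cnc3ncnc(Cl)c32)c1` derives from compound 1 by hydrogen in place of chloro on an aromatic carbon. For the measured compounds named here, no measured pair shows this step, so its size is unknown; a change of this kind is expected to lie within the scatter or to shift tolerance only modestly, in either direction. Compound 3 is expected to give about 80000 nM, within 30000 nM to 200000 nM.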

Compound 3, concentration lethal to 50% of the cells: 8120 nM
Estimate against measurement, compound 3: 9.9-fold (0.99 log units) above; the whole stated range lies above it.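

For the compounds shown here, compound 1 has no number to compare, so no step to compound 3 can be read. Going by these compounds, the effect of hydrogen in place of chloro on tolerance stays open, and no supporting data bear on the value of compound 3.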